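A few compounds are considered here, and "the series" means these few. Any claim that something is new, unique, unknown or untested is made for them only; others in the source may bear on it.

Compound 1, `CN(C)CCCCCSC1=Nc2ccccc2C(CC(=O)NCc2ccccc2)N1c1ccc(-c2ccc(F)cc2)cc1`, is tested in a functional assay on HCT-116 cells (Homo sapiens) for cytotoxicity, read by MTT assay, with a stated time of 48 h (a higher number here means a weaker inhibitor, a lower number a stronger inhibitor), where compound 1 gives 9200 nM. Compound 2, `O=C(CC1c2ccccc2N=C(SCCCCCN2CCCC2)N1c1ccc(-c2ccc(F)cc2)cc1)NCc1ccc(F)cc1`, carries a fluorobenzyl amide and a pyrrolidine at the end of the five-carbon chain, and in this assay compound 2 gives 7700 nM. Those two numbers lie within the usual scatter of each other, so no difference between compound 1 and compound 2 can be read from them.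

Compound 3, `O=C(CC1c2ccccc2N=C(SCCCCCN2CCCC2)N1c1ccc(-c2ccc(F)cc2)cc1)NCc1ccccc1`, differs from compound 2 in a single place: hydrogen in place of fluoro on an aromatic carbon, so that the 4-fluorobenzyl becomes a benzyl. Among the measured compounds shown here, no measured pair shows this change on its own. Compound 1 already carries an unsubstituted benzyl and sits close to compound 2, which suggests the change weighs little. The step of a 1.1-fold higher number from compound 2 to compound 3 (0.04 log units; within the scatter) is therefore expected to stay within the scatter, in no clear direction. Compound 3 is estimated at 8500 nM, somewhere between 4000 nM and 18000 nM.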

Compound 3, half-maximal inhibitory concentration: 12500 nM
For compound 3 the middle estimate is 1.5-fold (0.17 log units) below the measured one; measured number inside the range.
By their numbers in this assay, from the lowest: compounds 2, 1 and 3 (each within the scatter of the next).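

Hydrogen in place of fluoro on the aromatic carbon can now be read on its own in this assay, and the pair gives a 1.6-fold higher number from compound 2 to compound 3 (0.21 log units; within the scatter) as the first direct reading at this position. Compound 3 also allows a reading at the far end of the five-carbon chain, where pyrrolidin-1-yl in place of dimethylamino gives a 1.4-fold higher number from compound 1 to compound 3 (0.13 log units; within the scatter) in the same assay. Neither the fluoro nor the choice between these two amines separates the compounds beyond the usual scatter of repeated measurements.

Nothing available explains these numbers. As far as these compounds go, whether a chloro or methoxy group in place of the fluoro, or a piperidine or a longer chain at the amine end, would give a number beyond the scatter remains open.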